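Replacing a phenyl on the shared core: an expectation

A few compounds are considered here, and "the series" means these few. Any claim that something is new, unique, unknown or untested is made for them only; others in the source may bear on it.

Measured so far:
compound 1 `Cc1c(-n2c(-c3ccccc3)c(-c3ccccc3)c3c(Nc4ccccc4)ncnc32)n(C)n(-c2ccccc2)c1=O` gives 1.99%
compound 2 `Cc1nc2c(c(-c3ccccc3)c(-c3ccccc3)n2-c2c(C)c(=O)n(-c3ccccc3)n2C)c(=O)[nH]1` gives 2.16%
compound 3 `Cc1c(-n2c(N)c(C(N)=O)c(-c3ccccc3)c2-c2ccccc2)n(C)n(-c2ccccc2)c1=O` gives 19.1%

All three were tested in a functional assay on the whole organism (strain Sprague-Dawley) for inhibition, with Rattus norvegicus as the target, read by paw edema, with a stated time of 1 h, at a dose of 70 mg/kg by the subcutaneous route; a higher number here means more inhibition at the dose given (going by the name of the read-out), a lower number less inhibition. Compound 1 has the lowest number shown, but compound 2 lies within the usual scatter of it, so the two cannot be told apart; compound 3 sits beyond the scatter, higher. Compound 4 `Cc1c(-n2c(-c3ccccc3)c(-c3ccccc3)c3c(N/N=C/c4ccccc4)ncnc32)n(C)n(-c2ccccc2)c1=O` has not yet been measured. It differs from compound 1 in one place: a group of 8 heavy atoms (7 carbon, 1 nitrogen; one six-membered aromatic ring of carbon only) in place of a group of 6 heavy atoms (6 carbon; one six-membered aromatic ring of carbon only), on a nitrogen on an aromatic ring. Going by the values given here, no measured pair shows this change, so nothing is known of its effect. Resting on compound 1 alone, the step is expected to be small, a number 4 percentage points higher from compound 1 to compound 4 (within the scatter), with no direction clearly beyond the scatter. Compound 4 is therefore estimated to give 6%, most likely between -5% and 20%.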

Compound 4, a percentage reported as inhibition, in the whole organism at one dose (the size of the read-out at that dose, not a potency): 47.8%
Compound 4: the middle estimate sits 41.8 percentage points below what was measured, and the stated range ends below it.
By their numbers in this assay, from the lowest: compounds 1 and 2 (each within the scatter of the next); then compound 3; then compound 4.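

In this assay, the change at this position gives a number 45.8 percentage points higher from compound 1 to compound 4 (beyond the scatter), so swapping the phenyl on this nitrogen for the larger group can alter the result strongly on the core of compound 1. The entering group keeps the six-membered aromatic ring of carbon only and adds a nitrogen and a double bond outside aromatic rings. No available evidence gives a cause for this step.

Which part of the entering group matters remains open. So does whether a longer chain or a simple benzyl group at this place would give a similar step.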